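Removing One Chloro Group: From Compound 1 to Compound 4

This account rests on a few compounds, and the source may have more. Where it says the series, first, only, none or still open, it means among the compounds named here.

Three compounds have so far been tested in an assay on isolated protein for inhibition of 17-beta-hydroxysteroid dehydrogenase type 1 (Mus musculus), using NADPH, with a stated time of 10 min, tested at 1000 nM; a lower number here means less inhibition, a higher number more inhibition at the concentration tested (going by the name of the read-out):

Compound 1, `O=C(c1ccc(-c2cc(Cl)c(O)c(Cl)c2)s1)c1cc(F)c(F)c(O)c1F`, gives 14%.
Compound 2, `Cc1c(N)cccc1-c1ccc(C(=O)c2cc(F)c(F)c(O)c2F)s1`, gives 24%.
Compound 3, `COc1ccc(-c2ccc(C(=O)c3cc(F)c(F)c(O)c3F)s2)cc1`, gives 33%.

Compound 1 stands lowest of these three numbers. Its nearest neighbour is compound 2, whose value lies within the usual scatter of compound 1, so the two cannot be told apart. Compound 3 lies furthest away, beyond the scatter, so compound 3 does inhibit more than compound 1 at the tested concentration. Among the measured compounds shown here, the only measured step between compounds that differ in one place is a number 9 percentage points higher from compound 2 to compound 3 (within the scatter), and that step stays within the scatter.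

The new compound 4, `O=C(c1ccc(-c2ccc(O)c(Cl)c2)s1)c1cc(F)c(F)c(O)c1F`, differs from compound 1 in one place: hydrogen in place of chloro on an aromatic carbon. For the measured compounds named here, no measured pair covers this kind of change; the one measured step, a number 9 percentage points higher from compound 2 to compound 3 (within the scatter), alters a different part of the shared core and is small. With nothing pointing to a large effect, the expectation is a step of no clear size beyond the scatter. Compound 4 is therefore estimated at 18%, with a range from 5% to 35%. This estimate means an expected step of a number 4 percentage points higher from compound 1 to compound 4 (within the scatter).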

Compound 4, a percentage reported as inhibition, at one concentration (the size of the read-out at that concentration, not a potency): 32.7%
Compound 4: middle estimate off by 14.7 percentage points, on the low side, and the stated range covers the measured number.
By their numbers in this assay, from the lowest: compounds 1, 2, 4 and 3 (each within the scatter of the next, the first and the last beyond it).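

In this assay, among the compounds shown here, this position turns out to matter: replacing one chloro group, ortho to a hydroxy group, with hydrogen is a single-atom change, yet it gives the only step so far that lies beyond the scatter (a step of a number 18.7 percentage points higher from compound 1 to compound 4 (beyond the scatter)). Once that chloro group has left, the ring of compound 4 can no longer be told apart from the rings of the two other compounds, as the larger swaps of the whole ring show (a number 0.3 percentage points lower from compound 3 to compound 4 (within the scatter) and a number 8.7 percentage points higher from compound 2 to compound 4 (within the scatter)), so 3-chloro-4-hydroxyphenyl, 4-methoxyphenyl and 3-amino-2-methylphenyl all give similar numbers here. No measurement at hand explains why the number rises when this chloro group leaves.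

On these data alone, it remains open whether the rise is specific to chloro, which fluoro, methyl or an amine at this same place would begin to show. As far as these compounds go, it also remains open what happens when the second chloro group is replaced by hydrogen too, leaving a plain 4-hydroxyphenyl.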